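The source may report more compounds than this note shows. Statements on the series, on what has been measured and on what is new or still open speak of the compounds shown alone.

Compound 1 `O=C(/C=C/C=C/c1ccc(O)cc1)c1ccc(O)cc1`: > 100000 nM
Compound 2 `O=C(/C=C/C=C/c1ccc(O)cc1O)c1ccc(O)cc1`: > 100000 nM

In an ADME assay on RAW264.7 cells (Mus musculus) for cytotoxicity, read by MTT assay (on this read-out lower numbers stand for stronger inhibition and higher numbers for weaker inhibition), compound 1 gives > 100000 nM, which is a limit and not a number. Compound 2 gives > 100000 nM, again a limit. Going by the values given here, the one measured step, a step that the two limits leave unreadable from compound 1 to compound 2, therefore offers no size to build on, and the evidence amounts to the limit of > 100000 nM in this assay, at which 2 of the 2 values shown sit.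

Compound 3 `COc1ccc(/C=C/C=C/C(=O)c2ccc(O)cc2)c(O)c1` changes compound 2 by hydroxy to methoxy: methyl in place of hydrogen on an oxygen on an aromatic ring. With compound 2 at > 100000 nM, no change beyond the scatter is expected in this assay, and another limit is the likeliest report. The expected step is a number no higher from compound 2 to compound 3 (the limit leaves the size open). Compound 3 is estimated at 100000 nM, within an expected range of 30000 nM to 300000 nM.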

Compound 3, half-maximal inhibitory concentration: > 100000 nM
Compound 3 was reported as a limit; the forecaster's own chance of this, stated with the estimate: 80%; the middle value lies on the limit itself.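

Going by these compounds alone, compound 2 and compound 3 are both reported only as limits, not numbers, so no step between them can be read. The compounds shown leave open what actual value any of them has in this assay.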